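The source may report more compounds than this note shows. Statements on the series, on what has been measured and on what is new or still open speak of the compounds shown alone.

Of the compounds shown here, three of a shared core have been measured in a physicochemical assay for lipophilicity, using the shake flask method, in phosphate buffer, measured as octanol-water partition, at pH 7.4; a higher number here means a more lipophilic compound, a lower number a more polar compound. Compound 1 `COc1cc(-c2cc(C(=O)O)c3ccccc3n2)ccc1OCC(=O)Nc1cccc(Cl)c1` gives 2.3, compound 2 `COc1cc(-c2cc(C(=O)O)c3ccccc3n2)ccc1OCC(=O)Nc1ccc(Cl)cc1` gives 1.5, and compound 3 `COc1cc(-c2cc(C(=O)O)c3ccccc3n2)ccc1OCC(=O)Nc1ccc(C(F)(F)F)cc1` gives 1.6. Compound 3 thus stands second highest of the three numbers: its nearest neighbour is compound 2, separated by a number 0.10 log units higher from compound 2 to compound 3 (within the scatter), and its furthest is compound 1, separated by a number 0.70 log units lower from compound 1 to compound 3 (beyond the scatter). The remaining measured step, a number 0.80 log units lower from compound 1 to compound 2 (beyond the scatter), is of similar size.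

Compound 4 `COc1cc(-c2cc(C(=O)O)c3ccccc3n2)ccc1OCC(=O)NCc1ccccc1` has not yet been measured. It differs from compound 3 in one place: benzyl in place of 4-(trifluoromethyl)phenyl on an amide-type nitrogen. None of the three measured steps bears directly on this change, since each of them keeps an aryl group on the amide nitrogen and only moves or swaps a single substituent. Among the measured compounds shown here, the only step that touches the trifluoromethyl group, from compound 2 to compound 3, was within the scatter, which gives no guidance on replacing the whole aryl group with benzyl. The estimate for compound 4 is therefore held loosely: in this assay compound 4 is expected to give 1.1, with a range from 0.4 to 1.8, meaning an expected step of a number 0.50 log units lower from compound 3 to compound 4 (beyond the scatter) from compound 3.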

Compound 4, distribution coefficient: 0.4
The estimate for compound 4 lay 0.70 log units above the measured number, and the stated range covers the measured number.
By their numbers in this assay, from the lowest: compound 4; then compounds 2 and 3 (each within the scatter of the next); then compound 1.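

Placing benzyl on the amide-type nitrogen gives the largest changes seen so far in this assay: a number 1.20 log units lower from compound 3 to compound 4 (beyond the scatter), a number 1.10 log units lower from compound 2 to compound 4 (beyond the scatter) and a number 1.90 log units lower from compound 1 to compound 4 (beyond the scatter), which leaves compound 4 as the lowest of the four compounds. The earlier compounds shown here showed only changes among substituted phenyl groups at this position, the largest being a number 0.80 log units lower from compound 1 to compound 2 (beyond the scatter), whereas this result shows that replacing the whole group can move the number further, even though the carbon-only aromatic ring stays, the hydrogen-bond donor and acceptor counts of the group stay at zero and neither group carries a net charge. No measurement at hand explains why the number falls with this change.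

The compounds shown do not separate the loss of the chloro or trifluoromethyl substituent from the change from an aryl to a benzyl group on the nitrogen, since compound 4 differs from compounds 1, 2 and 3 in both respects. From the compounds shown here alone, an unsubstituted phenyl, a 4-chlorobenzyl or a longer chain such as 2-phenylethyl at the same place would bear on that, and how any of these would read remains open.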